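From 4-Hydroxyphenyl to 3-Hydroxyphenyl at the Assay Limit

The compounds below may be only part of what the source reports. "The series", "measured", "known", "first", "only" and "open" are said of these compounds alone.

In a functional assay on K562 cells (Homo sapiens) for antiproliferative activity, read by MTT assay, with a stated time of 24 h (on this read-out higher numbers stand for weaker inhibition and lower numbers for stronger inhibition), compound 2 (`COc1ccc(C(=O)/C=C/c2ccc(O)cc2)c2c1C=CC(C)(C)O2`) gives > 10000 nM. That value is a limit of the assay and not a number. Compound 1 (`COc1ccc(C(=O)/C=C/c2ccccc2Cl)c2c1C=CC(C)(C)O2`) gives > 10000 nM, which is also a limit. Among the measured compounds shown here, the only measured step, a step that the two limits leave unreadable from compound 1 to compound 2, therefore has no readable size, and the evidence comes down to the limit of > 10000 nM in this assay, at which 2 of the 2 values shown sit.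

Compound 3 (`COc1ccc(C(=O)/C=C/c2cccc(O)c2)c2c1C=CC(C)(C)O2`) has the same atoms as compound 2, joined differently: 3-hydroxyphenyl in place of 4-hydroxyphenyl on a double-bonded chain carbon bound to a double-bonded chain carbon. The 3-hydroxyphenyl group takes the place of 4-hydroxyphenyl, on a double-bonded chain carbon bound to a double-bonded chain carbon. The data show no direction for this change, so weak inhibition is the likely outcome, and this assay may again return only a limit. The expected change is a step that the limit leaves unreadable from compound 2 to compound 3, with no shift beyond the scatter anticipated. For compound 3 the estimated value is 12000 nM, with an expected range from 4000 nM to 30000 nM.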

Compound 3, half-maximal inhibitory concentration: > 10000 nM
Compound 3 gave a limit, no number; the forecaster's own chance of this, stated with the estimate: 70%; the middle value lies beyond the limit too.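

Among the compounds shown here, no step among compound 1, compound 2 and compound 3 can be read, as each value is a limit and not a number: the limit of > 10000 nM in this assay, at which 3 of the 3 values shown sit.

Still open, going by these compounds, is whether 2-chlorophenyl, 4-hydroxyphenyl and 3-hydroxyphenyl differ at all in this assay, and which change would give a readable number.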